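Three amide-to-acid variants of one core, and a fourth

This account rests on a few compounds, and the source may have more. Where it says the series, first, only, none or still open, it means among the compounds named here.

A set of three compounds sharing one core was examined in an assay on a protein complex for inhibition of CDK8/Cyclin C (Homo sapiens), with a stated time of 1 h, tested at 10 uM; on this read-out lower numbers stand for less inhibition and higher numbers for more inhibition at the one concentration tested (going by the name of the read-out). Compound 1, `CN1CCN(C(=O)/C=C/c2ccncc2-c2ccc3ccccc3c2)CC1`, gives 101% in this assay. Compound 2, `CNC(=O)/C=C/c1ccncc1-c1ccc2ccccc2c1`, gives 101%. Compound 3, `O=C(O)/C=C/c1ccncc1-c1ccc2ccccc2c1`, gives 102%. On these numbers compound 3 stands highest of the three, but only nominally: the step of a number 1 percentage points higher from compound 1 to compound 3 (within the scatter) and the step of a number 1 percentage points higher from compound 2 to compound 3 (within the scatter) are both within the scatter, as is no change at the digits printed from compound 1 to compound 2 (within the scatter), so the three compounds cannot be told apart in this assay.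

Compound 4, `COC1CN(C(=O)/C=C/c2ccncc2-c2ccc3ccccc3c2)C1`, has not yet been measured. It differs from compound 3 in this way: 3-methoxyazetidin-1-yl in place of hydroxy on a carbonyl carbon. Among the measured compounds shown here, the steps that bear on this change are the ones that swap one substituent on the carbonyl carbon for another, namely a number 1 percentage points higher from compound 1 to compound 3 (within the scatter) and a number 1 percentage points higher from compound 2 to compound 3 (within the scatter), and neither moved the read-out beyond the scatter. A 4-methylpiperazin-1-yl, a methylamino and a hydroxy on that carbonyl carbon all gave the same saturated read-out. Compound 4 is therefore expected to behave alike, with the step of a number 3 percentage points lower from compound 3 to compound 4 (within the scatter) estimated to stay within the scatter. The estimate for compound 4 in this assay is 99%, with a range from 88% to 106%.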

Compound 4, a percentage reported as inhibition, at one concentration (the size of the read-out at that concentration, not a potency): 100%
Estimate against measurement, compound 4: 1 percentage points below; low and high end bracket the measured number.
By their numbers in this assay, from the lowest: compounds 4, 1, 2 and 3 (each within the scatter of the next).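

In this assay, replacing the carboxy of compound 3 with (3-methoxyazetidin-1-yl)carbonyl gives a number 2 percentage points lower from compound 3 to compound 4 (within the scatter) and so removes the hydrogen-bond donor counted on the hydroxy without moving the read-out beyond the scatter. Among the compounds shown here, the position on the carbonyl carbon whose other neighbour is the double-bonded chain carbon thus also accepts a four-membered non-aromatic ring carrying a methoxy group, a kind of group the earlier compounds did not include, and the amide comparisons agree, with a number 1 percentage points lower from compound 2 to compound 4 (within the scatter) and with a number 1 percentage points lower from compound 1 to compound 4 (within the scatter) both reading as within the scatter. Nothing available explains why this read-out stays the same across these groups.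

Going by these compounds, whether an ethyl ester or a longer chain ending in an amine on that carbonyl carbon would also leave the read-out within the scatter remains open. On these data alone, with all four compounds inseparable at a single concentration, it also remains open whether these groups differ in potency, which a read-out of this kind cannot show.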